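The compounds below may be only part of what the source reports. "The series", "measured", "known", "first", "only" and "open" are said of these compounds alone.

Of the compounds shown here, three built on one shared core have been measured in a functional assay on HepG2 cells (Homo sapiens) for antiproliferative activity, read by MTT assay, with a stated time of 48 h; a lower number here means a stronger inhibitor, a higher number a weaker inhibitor. Compound 1 `Cc1ccccc1-n1nncc1CN1C(=O)C2(C(C#N)=C(N)Oc3c(N)cc4nc5ccccc5nc4c32)c2ccccc21` carries a 2-methylphenyl group on an aromatic nitrogen; in this assay compound 1 reaches only the limit > 50000 nM. Compound 2 `N#CC1=C(N)Oc2c(N)cc3nc4ccccc4nc3c2C12C(=O)N(Cc1cnnn1-c1cccc(C(F)(F)F)c1)c1ccccc12` bears a 3-(trifluoromethyl)phenyl group at that position, and in this assay compound 2 gives 15800 nM. Compound 3 `Cc1ccc(-n2nncc2CN2C(=O)C3(C(C#N)=C(N)Oc4c(N)cc5nc6ccccc6nc5c43)c3ccccc32)cc1C` bears a 3,4-dimethylphenyl group; in this assay compound 3 sits at the limit > 50000 nM. Compound 3 thus stands at the limit of > 50000 nM in this assay, at which 2 of the 3 values shown sit, with nothing more precise known for it. The measured steps are an at least 3.1-fold lower number from compound 1 to compound 2 (0.50 log units; beyond the scatter), an at least 3.1-fold higher number from compound 2 to compound 3 (0.50 log units; beyond the scatter) and a step that the two limits leave unreadable from compound 1 to compound 3.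

Compound 4 `N#CC1=C(N)Oc2c(N)cc3nc4ccccc4nc3c2C12C(=O)N(Cc1cnnn1-c1c(F)cccc1F)c1ccccc12` differs from compound 3 in one place: 2,6-difluorophenyl in place of 3,4-dimethylphenyl on an aromatic nitrogen. No measured step exchanges a dimethylphenyl for a difluorophenyl, so the steps shown bear on this change only indirectly. Moving from a methyl-bearing ring to a trifluoromethyl-bearing ring gave an at least 3.1-fold lower number from compound 1 to compound 2 (0.50 log units; beyond the scatter), whereas moving between two methyl-bearing rings, a step that the two limits leave unreadable from compound 1 to compound 3, could not be read. On this basis the expected step is an at least 1.6-fold lower number from compound 3 to compound 4 (0.22 log units; that floor lies within the scatter), toward a lower number but with wide uncertainty and a real chance that only a limit is again reported. The estimate for compound 4 in this assay is 30000 nM, with a range from 8000 nM to 100000 nM.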

Compound 4, half-maximal inhibitory concentration: > 50000 nM
Compound 4 gave a limit, no number; the forecaster's own chance of this, stated with the estimate: 50%; middle value at least 1.6-fold (0.22 log units) from the limit.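

Fluorine on the phenyl ring is not enough in itself at this position on the aromatic nitrogen: 2,6-difluorophenyl in place of 3-(trifluoromethyl)phenyl gives an at least 3.1-fold higher number from compound 2 to compound 4 (0.50 log units; beyond the scatter). Compound 2 thus remains the only one of the four to give a number, while the other three, with methyl-bearing or difluorophenyl rings, share one reading: the limit of > 50000 nM in this assay, at which 3 of the 4 values shown sit. The steps among those three cannot be read, since each has a limit at both ends, so these rings cannot be ordered against one another.

Going by these compounds, it remains open whether the trifluoromethyl group itself sets compound 2 apart, or whether a phenyl ring carrying a chlorine, a methoxy group or a carboxylic acid would also give a number in this assay. On these data alone, it is equally open how far the compounds at the limit differ from one another, and whether an amine or a longer chain placed elsewhere on the shared core would bring them into the measurable range.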